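A Methyl Group on the Ring Nitrogen of Compound 1

A few compounds are considered here, and "the series" means these few. Any claim that something is new, unique, unknown or untested is made for them only; others in the source may bear on it.

compound 1 `Oc1cccc(-c2nc(N3CCCCC3)c3nc[nH]c3n2)c1` — > 80%
compound 2 `CN1CCN(c2nc(-c3ccccc3O)nc3c2ncn3C)CC1` — 36%
compound 3 `CN1CCN(c2nc(-c3ccc(Cl)c(C(F)(F)F)c3)nc3[nH]cnc23)CC1` — 25.1%

All three were tested in an assay on cells for displacement of a labelled ligand from adenosine receptor A2b (Homo sapiens), read by scintillation counting and radioligand binding, with a stated time of 30 min, tested at 10 uM; a lower number here means less inhibition, a higher number more inhibition at the concentration tested (going by the name of the read-out). On these data alone, for compound 1 the result is not a number but a limit of the assay, (the limit of > 80% in this assay, at which 1 of the 3 values shown sits), so where it truly stands is unknown. Compound 2 gives 36% and compound 3 gives 25.1%. No two of these compounds differ in a single place, so no measured step can be drawn from them.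

Compound 4 `Cn1cnc2c(N3CCCCC3)nc(-c3cccc(O)c3)nc21` has not yet been measured in this assay. It differs from compound 1 by methyl in place of hydrogen on an aromatic nitrogen. Within the data shown here, no measured pair shows this change, so the expectation rests on the change alone. The step from compound 1 to compound 4 is expected to go downward, beyond the scatter, as a number at least 25 percentage points lower from compound 1 to compound 4 (beyond the scatter). Compound 4 is therefore estimated at 55%, with a likely range from 30% to 85%.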

Compound 4, a percentage reported as inhibition, at one concentration (the size of the read-out at that concentration, not a potency): 29.3%
Beside the measured number, compound 4's estimate is 25.7 percentage points above it; the measured number lies below the stated range.
By their numbers in this assay, from the lowest: compounds 3, 4 and 2 (each within the scatter of the next, the first and the last beyond it). At a limit, above all of these: compound 1.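

Among these compounds, for the first time, a single change at this position can be read: in this assay, methyl in place of hydrogen on the aromatic nitrogen gives a number at least 50.7 percentage points lower from compound 1 to compound 4 (beyond the scatter). On the core of compound 1, then, even this one added carbon at this nitrogen matters. The true size of the step remains unknown, since the result for compound 1 is a limit and not a number: the limit of > 80% in this assay, at which 1 of the 4 values shown sits.

On these data alone, it remains open whether the drop follows from losing the hydrogen or from adding the carbon. An ethyl group or a longer propyl chain on the same nitrogen could show whether inhibition keeps falling as the group grows.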